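The source may hold more compounds than are shown below. What is called first, only, known or untested is meant among the compounds shown, and "the series" means these compounds.

Compound 2 `CC1(C)[C@H]2CC[C@]1(C)N(Cc1cn(-c3ccccc3Cl)nn1)C(=O)C2` stands at the higher of the two numbers in an ADME assay on NCM460 cells (Homo sapiens) for cytotoxicity, read by MTT assay, with a stated time of 24 h (a higher number here means that more compound is tolerated, a lower number that less compound is tolerated), where compound 2 gives 10800 nM. Its neighbour compound 1 `CC1(C)[C@H]2CC[C@]1(C)N(Cc1cn(-c3ccc(C#N)cc3)nn1)C(=O)C2` gives 8140 nM, and the step of a 1.3-fold higher number from compound 1 to compound 2 (0.12 log units; within the scatter) shows that exchanging the aryl group on the aromatic nitrogen changed little. Compound 3 `CC1(C)[C@H]2CC[C@]1(C)N(Cc1cn(-c3cccc(Br)c3)nn1)C(=O)C2` differs from compound 2 by 3-bromophenyl in place of 2-chlorophenyl on an aromatic nitrogen. Within the data shown here, as this is again only an exchange of the aryl group, the one measured step bearing on it being a 1.3-fold higher number from compound 1 to compound 2 (0.12 log units; within the scatter), no step beyond the scatter is expected. Compound 3 is therefore estimated at 10000 nM, with a range of 4500 nM to 22000 nM, a step of a 1.1-fold lower number from compound 2 to compound 3 (0.03 log units; within the scatter).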

Compound 3, half-maximal cytotoxic concentration: 14600 nM
Compound 3: the middle estimate sits 1.5-fold (0.16 log units) below what was measured; the measured number falls inside the stated range.
By their numbers in this assay, from the lowest: compounds 1, 2 and 3 (each within the scatter of the next).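

In this assay the change to 3-bromophenyl gives little: (a 1.4-fold higher number from compound 2 to compound 3 (0.13 log units; within the scatter)) and (a 1.8-fold higher number from compound 1 to compound 3 (0.25 log units; within the scatter)). Even the pair that shares neither a substituent nor its place on the phenyl ring therefore stays within the scatter, so chlorine, bromine and nitrile on this aryl group give no readable difference at this position. Nothing available here accounts for this result. As far as these compounds go, whether an aryl group bearing an amine or a carboxylic acid, or a longer chain in place of the aryl group, would give a step beyond the scatter stays open, as does any change to the shared core.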